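The source may hold more compounds than are shown below. What is called first, only, known or untested is meant among the compounds shown, and "the series" means these compounds.

Of the compounds shown here, three built around a shared core have been tested in an assay on isolated protein for inhibition of malate dehydrogenase, mitochondrial (Sus scrofa), with stated times of 45 min and 30 min; on this read-out higher numbers stand for weaker inhibition and lower numbers for stronger inhibition. Compound 1 `O=S(=O)(Nc1ccc(-c2nc3ccccc3o2)cc1)c1ccc(Cl)s1` is one of them; in this assay compound 1 gives > 63000 nM, which is a limit of the assay rather than a measured number. Compound 2 `C=Cc1ccc(S(=O)(=O)Nc2ccc3oc(-c4ccccc4)nc3c2)cc1` gives > 63000 nM in this assay, again only a limit. Compound 3 `O=S(=O)(Nc1ccc2oc(-c3ccccc3)nc2c1)c1ccc(Cl)cc1` likewise gives > 63000 nM in this assay, a limit as well. Among the compounds with values here, the one step between measured compounds that differ in a single place, a step that the two limits leave unreadable from compound 2 to compound 3, has no readable size, with both of its ends sitting at the limit (the limit of > 63000 nM in this assay, at which 3 of the 3 values shown sit). Compound 1 thus stands nowhere above or below its two companions; all three share the same limit.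

Compound 4 `COc1cccc(S(=O)(=O)Nc2ccc(-c3nc4ccccc4o3)cc2)c1` has not yet been measured. It differs from compound 1 by 3-methoxyphenyl in place of 5-chlorothiophen-2-yl on a sulfonyl sulfur. Within the data shown here, no measured step touches this kind of exchange, and the single step that exists cannot be read, and nothing among the measured values suggests that the exchange brings compound 4 into the measurable range. The expectation is that compound 4 also reaches only the limit, with a step that the limit leaves unreadable from compound 1 to compound 4 expected to be no step beyond the scatter. Compound 4 is estimated at 100000 nM, expected to fall between 30000 nM and 400000 nM.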

Compound 4, half-maximal inhibitory concentration: > 63000 nM
Compound 4 gave a limit, no number (the forecaster's own chance of this, stated with the estimate: 85%); the middle value lies beyond the limit too.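

Like compound 1, compound 4 reaches only a limit, so swapping 5-chlorothiophen-2-yl for 3-methoxyphenyl on the sulfonyl sulfur gives no step that can be read between compound 1 and compound 4: the limit of > 63000 nM in this assay, at which 4 of the 4 values shown sit.

The compounds shown leave open whether any change to the shared core gives a true number in this assay, and how the groups on the sulfonyl sulfur rank against one another.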